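Chloroquinoline-ethylenediamine cinnamamides: Vero cytotoxicity notes

The source may report more compounds than this note shows. Statements on the series, on what has been measured and on what is new or still open speak of the compounds shown alone.

Three members of this series have been measured in an ADME assay on Vero cells (Chlorocebus sabaeus) for cytotoxicity, read by MTT assay, with a stated time of 72 h; a lower number here means that less compound is tolerated, a higher number that more compound is tolerated. Compound 1 `COc1cc(/C=C/C(=O)c2ccc(OCC(O)CNCCNc3ccnc4cc(Cl)ccc34)cc2)cc(OC)c1OC` gives 1910 nM. Compound 2 `COc1cc(OC)c(OC)cc1/C=C/C(=O)NCCNc1ccnc2cc(Cl)ccc12` gives 16100 nM. Compound 3 `Cc1ccc(/C=C/C(=O)NCCNc2ccnc3cc(Cl)ccc23)cc1` gives 4000 nM. Among these three numbers compound 3 stands second highest: its nearest neighbour is compound 1, whose number is lower and whose separation from compound 3 lies beyond the usual scatter, and its furthest neighbour is compound 2, whose number is higher and likewise beyond the scatter.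

Compound 4 `O=C(/C=C/c1ccco1)NCCNc1ccnc2cc(Cl)ccc12` has not yet been measured in this assay. It differs from compound 3 in one place: furan-2-yl in place of 4-methylphenyl on a double-bonded chain carbon bound to a double-bonded chain carbon.

Among the measured compounds shown here, no measured pair in the set shares exactly this change, so the expected step rests only on the spread seen so far. Compound 2, with a different substituted aryl group at the same position as compound 3, sits higher; compound 1, with a different arrangement of the whole molecule, sits lower. The step from compound 3 to compound 4 is expected to be small, likely upward but possibly within the scatter, as a 1.5-fold higher number from compound 3 to compound 4 (0.18 log units; within the scatter). Compound 4 is therefore estimated to give 6000 nM in this assay, with a plausible range from 2500 nM to 15000 nM.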

Compound 4, half-maximal cytotoxic concentration: 629000 nM
Compound 4: middle estimate off by 100-fold (2.02 log units), on the low side, and the stated range ends below it.
By their numbers in this assay, from the lowest: compound 1; then compound 3; then compound 2; then compound 4.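

In this assay, furan-2-yl in place of 4-methylphenyl on a double-bonded chain carbon bound to a double-bonded chain carbon gives a 160-fold higher number from compound 3 to compound 4 (2.20 log units; beyond the scatter) and makes compound 4 the highest of the four numbers. Among the compounds shown here, this is the only step so far that isolates a single place, and it shows that this position alone can move the number by a large margin, well beyond the scatter. The change replaces a six-membered aromatic ring of carbon only, with 7 heavy atoms, by a five-membered aromatic ring of 5 heavy atoms that includes 1 oxygen and brings 1 hydrogen-bond acceptor, and nothing at hand accounts for the size of the step.

From the compounds shown here alone, what stays open is which part of the exchange carries the step: the ring size, the ring oxygen or the loss of the methyl group. Plain phenyl and thiophen-2-yl at this same place would begin to separate these, and only further single-place pairs could show whether the step holds on other members of the series.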